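Chloro added to the phenoxy ring of compound 3

This account rests on a few compounds, and the source may have more. Where it says the series, first, only, none or still open, it means among the compounds named here.

Measured compounds:
compound 1, `Cc1cc(Cl)c(S(C)(=O)=O)cc1C(=O)N=C(N)N`, 25 nM
compound 2, `Cc1c(C(=O)N=C(N)N)cc(S(C)(=O)=O)c(Cl)c1Cl`, 29 nM
compound 3, `Cc1cc(Oc2ccccc2)c(S(C)(=O)=O)cc1C(=O)N=C(N)N`, 10 nM

All three were run in a functional assay for inhibition of sodium/hydrogen exchanger (Oryctolagus cuniculus); a higher number here means a weaker inhibitor, a lower number a stronger inhibitor. Compound 1 is the reference point. Compound 2 differs from it by chloro in place of hydrogen on an aromatic carbon, and the step is a 1.2-fold higher number from compound 1 to compound 2 (0.06 log units; within the scatter). Compound 3 differs from compound 1 by phenoxy in place of chloro on an aromatic carbon, and here the step is a 2.5-fold lower number from compound 1 to compound 3 (0.40 log units; beyond the scatter). Compound 3 thus carries the lowest number of the three, and its steps to compound 1 and to compound 2 are both beyond the scatter.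

Compound 4, `Cc1cc(Oc2ccccc2Cl)c(S(C)(=O)=O)cc1C(=O)N=C(N)N`, is not yet measured. It differs from compound 3 by chloro in place of hydrogen on an aromatic carbon. This is the same kind of change as from compound 1 to compound 2, but not the same: in compound 2 the entering chloro sits ortho to a chloro group, ortho to a methyl group, meta to a group of 6 heavy atoms and meta to a methylsulfonyl group on the shared core, whereas in compound 4 it sits on the phenoxy ring, ortho to a large group. For the measured compounds named here, the only measured step of this kind, a 1.2-fold higher number from compound 1 to compound 2 (0.06 log units; within the scatter), lies within the scatter.

On that basis the expected step is a 1.1-fold lower number from compound 3 to compound 4 (0.05 log units; within the scatter), small and not clearly distinguishable from no change. The estimate for compound 4 is 9 nM, with a range from 4 nM to 20 nM.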

Compound 4, half-maximal inhibitory concentration: 14 nM
Compound 4: middle estimate off by 1.6-fold (0.19 log units), on the low side; low and high end bracket the measured number.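

Chloro in place of hydrogen on the phenoxy ring gives a 1.4-fold higher number from compound 3 to compound 4 (0.15 log units; within the scatter) in this assay, while 2-chlorophenoxy in place of chloro on the shared core gives a 1.8-fold lower number from compound 1 to compound 4 (0.25 log units; within the scatter). Set beside the earlier chloro step, this step shows no detectable difference between the two cores: the same change on two cores in this assay, a 1.2-fold higher number (0.06 log units; within the scatter) from compound 1 to compound 2 and a 1.4-fold higher number (0.15 log units; within the scatter) from compound 3 to compound 4, 1.2-fold (0.08 log units) apart, within the scatter of two such steps. For the compounds shown here, the agreement shows only that the change stayed within the scatter in both pairs; it does not show a shared effect of chloro, as neither step can be told from no change, and two pairs at two different places on two cores set no rule for the series.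

Still open, as far as these compounds go, is whether a different group at the same place on the phenoxy ring, such as methoxy, an amine or a carboxylic acid, would produce a step beyond the scatter. Also open, from the compounds shown here alone, is whether chloro at another place on the phenoxy ring would stay as close to no change as it does in compound 4.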